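A few compounds are considered here, and "the series" means these few. Any claim that something is new, unique, unknown or untested is made for them only; others in the source may bear on it.

Three compounds sharing one core were tested in a functional assay on MGC-803 cells (Homo sapiens) for antiproliferative activity, read by CCK-8 assay, with a stated time of 72 h; on this read-out higher numbers stand for weaker inhibition and lower numbers for stronger inhibition. Compound 1 `CN1CCCN(c2ccn3c(-c4ccc(NC(=O)c5ccc([N+](=O)[O-])o5)cc4)cnc3c2)CC1` gives 3580 nM. Compound 2 `O=C(Nc1ccc(-c2cnc3cc(Cl)ccn23)cc1)c1ccc([N+](=O)[O-])o1` gives 4620 nM, and compound 3 `COc1ccn2c(-c3ccc(NC(=O)c4ccc([N+](=O)[O-])o4)cc3)cnc2c1` gives 860 nM. The step from compound 1 to compound 2 is a 1.3-fold higher number from compound 1 to compound 2 (0.11 log units; within the scatter), so these two cannot be told apart. Compound 3 gives the lowest number of the three: the step to it is a 4.2-fold lower number from compound 1 to compound 3 (0.62 log units; beyond the scatter) and, from the other side, a 5.4-fold lower number from compound 2 to compound 3 (0.73 log units; beyond the scatter). Among the three measured compounds, compound 3 is thus the strongest inhibitor.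

Compound 4 `COc1ccn2c(-c3ccc(NC(=O)c4ccc([N+](=O)[O-])o4)c(OC)c3)cnc2c1` has not yet been measured. It differs from compound 3 by methoxy in place of hydrogen on an aromatic carbon. All three measured steps alter the group attached to the shared core; the change to compound 4 leaves that group as in compound 3 and adds a methoxy elsewhere. Among the measured compounds shown here, none of the measured steps therefore bears directly on this change, and the numbers give no basis for predicting a shift in either direction. The expectation is a result close to that of compound 3, with no step beyond the usual scatter. In this assay the expected step is a 1.0-fold higher number from compound 3 to compound 4 (0.02 log units; within the scatter). Compound 4 is expected to give about 900 nM, within a range from 300 nM to 2700 nM.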

Compound 4, half-maximal inhibitory concentration: 7520 nM
Beside the measured number, compound 4's estimate is 8.4-fold (0.92 log units) below it, outside the stated range (above it).
By their numbers in this assay, from the lowest: compound 3; then compounds 1, 2 and 4 (each within the scatter of the next, the first and the last beyond it).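

This is the first change shown on the six-membered aromatic ring of carbon only, ortho to a large group and meta to a large group, rather than on the group attached to the shared core. In this assay, methoxy in place of hydrogen at this position gives an 8.7-fold higher number from compound 3 to compound 4 (0.94 log units; beyond the scatter), so the position is sensitive to substitution, and a group of just 2 heavy atoms is enough to weaken inhibition beyond the usual scatter. Nothing available explains why this single addition has so clear an effect.

With only hydrogen and methoxy shown at this position, it remains open whether a fluorine atom, a methyl group or a hydroxyl group would weaken inhibition to a similar extent, or whether any group at all can be placed here without a loss. As far as these compounds go, it is also open whether methoxy has the same effect at other carbons of this ring, or when chloro or 4-methyl-1,4-diazepan-1-yl replaces the methoxy on the shared core.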